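The compounds below may be only part of what the source reports. "The series", "measured", "known", "first", "only" and "open" are said of these compounds alone.

Measured compounds:
- compound 1, `COc1cccc(C(=O)Oc2cc3c(cc2C)[C@@H](C(C)C)CC=C3C)c1`: "not active" (no number reported)
- compound 2, `CC1=CC[C@H](C(C)C)c2cc(C)c(OC(=O)c3ccc(Cl)cc3)cc21`: 47.4%
- compound 3, `CC1=CC[C@H](C(C)C)c2cc(C)c(OC(=O)c3cccc([N+](=O)[O-])c3)cc21`: 45.9%

In a functional assay on HCT-15 cells (Homo sapiens) for antiproliferative activity, read by sulforhodamine B assay, with a stated time of 48 h, tested at 50 uM (on this read-out higher numbers stand for more inhibition at the one concentration tested (going by the name of the read-out) and lower numbers for less inhibition), compound 3 stands lowest of the two compounds with a number; its nearest neighbour is compound 2, and the step of a number 1.5 percentage points lower from compound 2 to compound 3 (within the scatter) lies within the scatter, so the two cannot be ordered. Compound 1 is reported only as not active in this assay.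

Compound 4, `CC1=CC[C@H](C(C)C)c2cc(C)c(OC(=O)c3ccc(C)cc3)cc21`, has not yet been measured. It differs from compound 3 by 4-methylphenyl in place of 3-nitrophenyl on a carbonyl carbon. Within the data shown here, only one measured step bears on this change, the exchange of one aromatic group on the carbonyl carbon between compound 2 and compound 3, and that step was small, within the scatter. As far as these compounds go, compound 1, which carries a 3-methoxyphenyl group at the same place, shows that not every such exchange keeps the activity; a 4-methylphenyl group is untested here. Compound 4 is therefore expected to give about 40% in this assay, between 15% and 55%, with the estimated step of a number 5.9 percentage points lower from compound 3 to compound 4 (within the scatter) leaning slightly downward but not clearly beyond the scatter.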

Compound 4, a percentage reported as inhibition, at one concentration (the size of the read-out at that concentration, not a potency): 78.9%
Compound 4: middle estimate off by 38.9 percentage points, on the low side; the measured number lies above the stated range.
By their numbers in this assay, from the lowest: compounds 3 and 2 (each within the scatter of the next); then compound 4.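

In this assay, among these compounds, the aromatic group on the carbonyl carbon proves able to change the result: a number 33 percentage points higher from compound 3 to compound 4 (beyond the scatter), whereas the only earlier step with two numbers stayed within the scatter. The closest comparison is a number 31.5 percentage points higher from compound 2 to compound 4 (beyond the scatter), and since methyl in place of chloro on an aromatic carbon is the only difference, this single exchange accompanies the whole rise. Nothing available explains the rise.

The compounds shown leave open whether methyl is special on that aromatic carbon or whether an ethyl group, a methoxy group or an amine would serve as well. They also leave open how 3-methylphenyl on the carbonyl carbon would compare with 4-methylphenyl, given that compound 1, with its 3-methoxyphenyl group, is "not active" (no number reported).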